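Chloro in place of methyl on the phenyl group

This account rests on a few compounds, and the source may have more. Where it says the series, first, only, none or still open, it means among the compounds named here.

Compound 1 `Nc1nc(N)c2cc(CSC(=S)N3CCN(c4ccccc4)CC3)ccc2n1`: 2840 nM
Compound 2 `Cc1ccc(N2CCN(C(=S)SCc3ccc4nc(N)nc(N)c4c3)CC2)cc1`: 2130 nM
Compound 3 `Nc1nc(N)c2cc(CSC(=S)N3CCN(c4ccc(Cl)cc4)CC3)ccc2n1`: 6990 nM

All three values come from a functional assay on HeLa cells (Homo sapiens) for antiproliferative activity, read by MTT assay, with a stated time of 72 h; on this read-out lower numbers stand for stronger inhibition and higher numbers for weaker inhibition. Compound 2 shares the low end of these numbers with one neighbour, as a 1.3-fold lower number from compound 1 to compound 2 (0.12 log units; within the scatter) shows, while a 3.3-fold higher number from compound 2 to compound 3 (0.52 log units; beyond the scatter) sets it apart from the third.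

Compound 4 `Nc1nc(N)c2cc(CSC(=S)N3CCN(c4ccccc4Cl)CC3)ccc2n1` remains unmeasured. Its change from compound 2 is 2-chlorophenyl in place of 4-methylphenyl on an amine nitrogen in a ring. The closest guide is the chloro step, a 2.5-fold higher number from compound 1 to compound 3 (0.39 log units; beyond the scatter), alongside the chloro-for-methyl step above. Among the compounds with values here, no measured compound carries the 2-chlorophenyl group, so a modest rise is expected, with wide uncertainty. The expected step is a 2.1-fold higher number from compound 2 to compound 4 (0.32 log units; beyond the scatter). Compound 4 is estimated at 4500 nM, with an expected range of 1800 nM to 11000 nM.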

Compound 4, half-maximal inhibitory concentration: 4050 nM
For compound 4 the middle estimate is 1.1-fold (0.05 log units) above the measured one; the measured number falls inside the stated range.
By their numbers in this assay, from the lowest: compounds 2, 1, 4 and 3 (each within the scatter of the next, the first and the last beyond it).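

In this assay the 2-chlorophenyl group stays within the scatter of the unsubstituted phenyl group (a 1.4-fold higher number from compound 1 to compound 4 (0.15 log units; within the scatter)) and of the 4-methylphenyl group (a 1.9-fold higher number from compound 2 to compound 4 (0.28 log units; within the scatter)), whereas the 4-chlorophenyl group was beyond it from both. Yet the two chlorophenyl groups cannot be told apart (a 1.7-fold lower number from compound 3 to compound 4 (0.24 log units; within the scatter)), so these numbers set no order between them. No evidence here bears on these results. As far as these compounds go, how a methoxy or fluoro group on the phenyl ring would read stays open, as does any change to the shared core.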